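A few compounds are considered here, and "the series" means these few. Any claim that something is new, unique, unknown or untested is made for them only; others in the source may bear on it.

In a functional assay on MCF7 cells (Homo sapiens) for inhibition (a lower number here means a stronger inhibitor, a higher number a weaker inhibitor), compound 3 `CC/C(=C(/c1ccc(/C=C/C(=O)O)cc1)c1cc2ccccc2[nH]1)c1ccc(F)cc1Cl` gives 39 nM, the second highest of the three numbers. Compound 1 `CC/C(=C(/c1ccc(/C=C/C(=O)O)cc1)c1cc2ccccc2[nH]1)c1ccccc1C#N` gives 9 nM and compound 2 `CC/C(=C(/c1ccc(/C=C/C(=O)O)cc1)c1cc2ccccc2[nH]1)c1ccc(C(F)(F)F)cc1` gives 139 nM. Every measured step swaps the aryl group on the double-bonded chain carbon: a 15-fold higher number from compound 1 to compound 2 (1.19 log units; beyond the scatter), a 4.3-fold higher number from compound 1 to compound 3 (0.64 log units; beyond the scatter) and a 3.6-fold lower number from compound 2 to compound 3 (0.55 log units; beyond the scatter). Compound 4 `CC/C(=C(/c1ccc(/C=C/C(=O)O)cc1)c1cc2ccccc2[nH]1)c1ccc(C#N)cc1Cl` differs from compound 3 by cyano in place of fluoro on an aromatic carbon. Within the data shown here, no measured step changes only this position, so the bearing of the three steps is indirect: they show that changing this ring moves the number by modest to large amounts, and compound 1, which carries 2-cyanophenyl, has the lowest number. A modest step in this assay is therefore expected, its direction uncertain. Compound 4 is estimated at 50 nM, between 15 nM and 160 nM, which means a 1.3-fold higher number from compound 3 to compound 4 (0.11 log units; within the scatter) is expected.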

Compound 4, half-maximal inhibitory concentration: 49 nM
For compound 4 the middle estimate is 1.0-fold (0.01 log units) above the measured one, and the stated range covers the measured number.
By their numbers in this assay, from the lowest: compound 1; then compounds 3 and 4 (each within the scatter of the next); then compound 2.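

In this assay, cyano in place of fluoro, para to a large group and meta to a chloro group, gives a change within the scatter (a 1.3-fold higher number from compound 3 to compound 4 (0.10 log units; within the scatter)), so this position, with the chloro group kept, tolerates either group. Replacing the whole aryl group still matters, with a 2.8-fold lower number from compound 2 to compound 4 (0.45 log units; beyond the scatter) and a 5.4-fold higher number from compound 1 to compound 4 (0.74 log units; beyond the scatter) both beyond the scatter. No supporting data explain this result.

From the compounds shown here alone, it remains open whether an amine or a methoxy group at this position would behave likewise. Whether cyano and fluoro would also match without the chloro group is open too.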